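The source may hold more compounds than are shown below. What is called first, only, known or untested is meant among the compounds shown, and "the series" means these compounds.

Compound 1 `N#Cc1cnc(C(O)CCCCCCc2ccccc2)o1` carries a nitrile on the shared core, and in an assay (Rattus norvegicus) for inhibition of Fatty-acid amide hydrolase 1 (Homo sapiens) (a lower number here means a stronger inhibitor, a higher number a weaker inhibitor), compound 1 gives 4200 nM. Compound 2 `NC(=O)c1cnc(C(O)CCCCCCc2ccccc2)o1` carries a carbamoyl group in its place; in this assay compound 2 gives 25000 nM. That exchange was a 6.0-fold higher number from compound 1 to compound 2 (0.77 log units; beyond the scatter). Compound 3 `O=C(O)c1cccc(-c2cnc(C(O)CCCCCCc3ccccc3)o2)n1` carries a 6-carboxypyridin-2-yl group on the same aromatic carbon. In this assay compound 3 gives > 10000 nM, which is a limit of the assay and not a number. Compound 3 therefore stands apart from the other two values as a limit. The steps to it read as an at least 2.3-fold higher number from compound 1 to compound 3 (0.37 log units; beyond the scatter) and as a step that the limit leaves unreadable from compound 2 to compound 3. Compound 4 `O=C(O)c1ccc(-c2cnc(C(O)CCCCCCc3ccccc3)o2)nc1` differs from compound 3 only in the carboxypyridyl group: 5-carboxypyridin-2-yl in place of 6-carboxypyridin-2-yl on an aromatic carbon. Within the data shown here, no measured step mirrors this change; the only steps that bear on compound 4 are those to compound 3, and the limit of > 10000 nM in this assay, at which 1 of the 3 values shown sits, leaves their full size unknown. With compound 3 at the limit, the step that the limit leaves unreadable from compound 3 to compound 4 is expected to be small. Compound 4 is therefore estimated at 15000 nM, between 4000 nM and 60000 nM.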

Compound 4, inhibition constant: 45000 nM
Estimate against measurement, compound 4: 3.0-fold (0.48 log units) below, within the range that was stated.
By their numbers in this assay, from the lowest: compound 1; then compounds 2 and 4 (each within the scatter of the next).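

Among these compounds, compound 4 gives the first actual number for a carboxypyridyl group on this aromatic carbon. In this assay, replacing the carbamoyl group with 5-carboxypyridin-2-yl gives a 1.8-fold higher number from compound 2 to compound 4 (0.26 log units; within the scatter), so the two groups cannot be told apart, whereas replacing the nitrile gives an 11-fold higher number from compound 1 to compound 4 (1.03 log units; beyond the scatter), a large loss that the limit for compound 3 could only hint at. Compound 3 remains a limit of the assay and not a number, so the step from it to compound 4 cannot be read: the limit of > 10000 nM in this assay, at which 1 of the 4 values shown sits.

The compounds shown therefore leave open whether 5-carboxypyridin-2-yl and 6-carboxypyridin-2-yl differ at all in this assay. They also leave open how a methyl ester in place of the carboxylic acid would read on this carbon.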